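The source may report more compounds than this note shows. Statements on the series, on what has been measured and on what is new or still open speak of the compounds shown alone.

In an assay on isolated protein for inhibition of histone deacetylase 4 (Homo sapiens), with a stated time of 1 h (on this read-out higher numbers stand for weaker inhibition and lower numbers for stronger inhibition), the three measured compounds span a moderate range. Compound 1 `O=C(CN1C(=O)S/C(=C/c2ccccn2)C1=O)Nc1nc2ccccc2s1` gives 9300 nM. Compound 2 `O=C(COc1ccc2cc(/C=C3/SC(=O)NC3=O)ccc2c1)Nc1ccc(F)cc1` gives 1600 nM in this assay, the second highest of the three numbers; its nearest neighbour is compound 3 `Cc1cccc(NC(=O)COc2ccc3cc(/C=C4/SC(=O)NC4=O)ccc3c2)n1`, which gives 1100 nM, while compound 1 stands furthest from it. Within the data shown here, the only step measured at the amide-type nitrogen, a 1.5-fold lower number from compound 2 to compound 3 (0.16 log units; within the scatter), exchanged one aromatic group for another without leaving the scatter.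

Compound 4 `Cc1cc(Br)ccc1NC(=O)COc1ccc2cc(/C=C3/SC(=O)NC3=O)ccc2c1` differs from compound 2 by 4-bromo-2-methylphenyl in place of 4-fluorophenyl on an amide-type nitrogen. Among the measured compounds shown here, since the one comparable step, from compound 2 to compound 3, was within the scatter, and nothing else in the measured set bears on a 4-bromo-2-methylphenyl group at this position, the expectation in this assay is a step of modest size at most, with no confident direction; the expected step is a 1.1-fold lower number from compound 2 to compound 4 (0.06 log units; within the scatter). For compound 4 the estimated value in this assay is 1400 nM, expected to lie between 600 nM and 3500 nM.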

Compound 4, half-maximal inhibitory concentration: 550 nM
Estimate against measurement, compound 4: 2.5-fold (0.41 log units) above; the whole stated range lies above it.
By their numbers in this assay, from the lowest: compounds 4, 3 and 2 (each within the scatter of the next, the first and the last beyond it); then compound 1.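

In this assay, the group on the amide-type nitrogen can shift the number beyond the scatter, which the earlier pair at this position did not show: 4-bromo-2-methylphenyl in place of 4-fluorophenyl gives a 2.9-fold lower number from compound 2 to compound 4 (0.46 log units; beyond the scatter). The other new step at this nitrogen, a 2.0-fold lower number from compound 3 to compound 4 (0.30 log units; within the scatter), stays within the scatter, so 4-bromo-2-methylphenyl and 6-methylpyridin-2-yl cannot be told apart here, and only compound 2 is separated from compound 4. Nothing available accounts for the step from compound 2 to compound 4.

From the compounds shown here alone, the bromine and the methyl enter together, so the share of each in that step stays open. Also open, going by these compounds, is how a saturated amine such as piperidine would read in place of the aromatic group on this nitrogen.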